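Sulfonyl substituent change in a bis-sulfonyl piperidine series

The source may hold more compounds than are shown below. What is called first, only, known or untested is meant among the compounds shown, and "the series" means these compounds.

For the measured compounds named here, compound 2 `CCNS(=O)(=O)c1ccc(S(=O)(=O)N2CCC[C@@H](C(=O)N3CCN(c4nc(C(C)C)no4)CC3)C2)cc1` stands at the weaker end of the two numbers so far: in a functional assay on MIA PaCa-2 cells (Homo sapiens) for inhibition, read by MTT assay, with a stated time of 7 days (on this read-out lower numbers stand for stronger inhibition and higher numbers for weaker inhibition), compound 2 gives 3300 nM. Going by the values given here, its partner compound 1 `CCN(CC)S(=O)(=O)c1ccc(S(=O)(=O)N2CCC[C@@H](C(=O)N3CCN(c4nc(C(C)C)no4)CC3)C2)cc1` gives 50 nM in this assay, and the single measured step, a 66-fold higher number from compound 1 to compound 2 (1.82 log units; beyond the scatter), is the only comparison available. Compound 3 `CCC(CC)S(=O)(=O)c1ccc(S(=O)(=O)N2CCC[C@@H](C(=O)N3CCN(c4nc(C(C)C)no4)CC3)C2)cc1` has not been measured. It differs from compound 2 by pentan-3-yl in place of ethylamino on a sulfonyl sulfur; cut one bond further out, the change reads ethylsulfamoyl to (pentan-3-yl)sulfonyl, so the hydrogen-bond donor of compound 2 is gone and two ethyl groups are present again, as in compound 1, though here on a carbon joined to the sulfonyl sulfur rather than on a nitrogen. The step from compound 1 to compound 2 bears on this: removal of one ethyl from the sulfonamide nitrogen raised the number markedly, which suggests that restoring two ethyl groups should lower it. On these data alone, whether a carbon centre matches the nitrogen of compound 1 is untested in this set, so the estimate is kept broad. Compound 3 is expected at 200 nM (range 40 nM to 1500 nM), an expected step of a 17-fold lower number from compound 2 to compound 3 (1.22 log units; beyond the scatter).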

Compound 3, half-maximal inhibitory concentration: 50 nM
Estimate against measurement, compound 3: 4.0-fold (0.60 log units) above; the measured number falls inside the stated range.
By their numbers in this assay, from the lowest: compounds 1 and 3 (each within the scatter of the next); then compound 2.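

In this assay, pentan-3-yl in place of ethylamino on a sulfonyl sulfur gives a 66-fold lower number from compound 2 to compound 3 (1.82 log units; beyond the scatter) and so recovers the whole of the loss seen with compound 2, while pentan-3-yl in place of diethylamino gives no change at the digits printed from compound 1 to compound 3 (within the scatter) at this same position. A sulfonamide nitrogen is therefore not required for the low number in this pair: a sulfonyl sulfur carrying pentan-3-yl and one carrying diethylamino cannot be told apart in this assay, and compound 2, with its ethylamino group and hydrogen-bond donor, stands alone at the high end. Nothing available explains why these groups on the sulfonyl sulfur give such different numbers.

Still open, on these data alone, is whether propyl, which has a single chain and no hydrogen-bond donor, would group with compound 2 or with compounds 1 and 3, a comparison that would separate the loss of the amine hydrogen from the loss of the second ethyl group. The reach of this position is also open, as the shown compounds include neither a cyclopentyl or piperidin-1-yl group on the sulfonyl sulfur nor a longer chain such as dipropylamino.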